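The source may report more compounds than this note shows. Statements on the series, on what has been measured and on what is new or still open speak of the compounds shown alone.

Compound 1, `CN1CCC(C(=O)N(CC(=O)Nc2cc(F)cc(F)c2)C2CCCCC2)CC1`, gives > 25100 nM in an assay on HEK293 cells for inhibition of sodium- and chloride-dependent glycine transporter 1 (Homo sapiens), read by scintillation proximity assay; on this read-out lower numbers stand for stronger inhibition and higher numbers for weaker inhibition; this value is a limit of the assay, not a number.
Compound 2, `O=C(CN(C(=O)C1CCCCC1)C1CCCCC1)Nc1cc(F)cc(F)c1`, gives 6310 nM in this assay.

Going by the values given here, compound 2 is the only compound here with a measured number in this assay; the other value shown is a limit. Among the compounds with values here, the single measured step, an at least 3.9-fold lower number from compound 1 to compound 2 (0.59 log units; beyond the scatter), is all the evidence, and the limit of > 25100 nM in this assay, at which 1 of the 2 values shown sits, bounds how far that step can be read. Compound 3, `O=C(CN(C(=O)c1cccnc1)C1CCCCC1)Nc1cc(F)cc(F)c1`, differs from compound 2 by pyridin-3-yl in place of cyclohexyl on a carbonyl carbon. This change is not the one that was measured: it exchanges a non-aromatic ring for an aromatic ring with one hydrogen-bond acceptor, whereas the measured step replaced 1-methylpiperidin-4-yl with cyclohexyl. The measured step therefore gives no firm direction, and a step within the scatter or a modestly higher number is expected for a 1.6-fold higher number from compound 2 to compound 3 (0.20 log units; within the scatter). Compound 3 is estimated at 10000 nM, with a range from 3000 nM to 30000 nM.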

Compound 3, half-maximal inhibitory concentration: > 25100 nM
Compound 3: a limit, no number; the forecaster's own chance of this, stated with the estimate: 30%; middle value at least 2.5-fold (0.39 log units) from the limit.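

Putting pyridin-3-yl in place of cyclohexyl on this carbonyl carbon gives an at least 3.9-fold higher number from compound 2 to compound 3 (0.59 log units; beyond the scatter) in this assay, so here this aromatic ring with a nitrogen does not stand in for the all-carbon ring. Compound 3 gives > 25100 nM, which is a limit of the assay and not a number. Among these three compounds, the two groups holding a nitrogen, in compound 1 and compound 3, both end at a limit and only the cyclohexyl of compound 2 gives a measured number, so the full size of the loss cannot be read: the limit of > 25100 nM in this assay, at which 2 of the 3 values shown sit.

The step from compound 1 to compound 3 cannot be read, as both values are limits. Going by these compounds, a plain phenyl ring on the same carbonyl carbon would help to show whether the loss follows the aromatic ring or its nitrogen, and that question stays open.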